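Aryl swap on the shared core: outlook for compound 4

The source may hold more compounds than are shown below. What is called first, only, known or untested is meant among the compounds shown, and "the series" means these compounds.

Three measured compounds share one core and differ only in the aryl group attached to it. In a functional assay for inhibition, tested at 40 ug/mL (on this read-out lower numbers stand for a weaker effect and higher numbers for a stronger effect at the one concentration tested), compound 1 `COc1ccc(-c2cc(-c3cc(C(C)C)c(O)cc3C)[nH]c(=O)c2C#N)c(OC)c1` gives 37.5%. Compound 2 `COc1ccc(-c2cc(-c3cc(C(C)C)c(O)cc3C)[nH]c(=O)c2C#N)cc1OC` gives 44% in this assay, and compound 3 `Cc1cc(O)c(C(C)C)cc1-c1cc(-c2ccc(N(C)C)cc2)c(C#N)c(=O)[nH]1` gives 43% in this assay. Compound 3 is separated from its neighbours by a number 1 percentage points lower from compound 2 to compound 3 (within the scatter) and a number 5.5 percentage points higher from compound 1 to compound 3 (within the scatter), both within the scatter, so the three numbers cannot be told apart.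

Compound 4 `Cc1cc(O)c(C(C)C)cc1-c1cc(-c2ccccc2[N+](=O)[O-])c(C#N)c(=O)[nH]1` carries a further aryl group at the same place: 2-nitrophenyl in place of 4-(dimethylamino)phenyl on an aromatic carbon. Within the data shown here, the steps that bear on this change are the three aryl swaps already measured, a number 6.5 percentage points higher from compound 1 to compound 2 (within the scatter), a number 5.5 percentage points higher from compound 1 to compound 3 (within the scatter) and a number 1 percentage points lower from compound 2 to compound 3 (within the scatter). Among the measured compounds shown here, each lies within the scatter, and the measured set gives no example of an aryl swap at this place that moves this assay beyond it. Nothing in the data therefore points to a shift in either direction for the 2-nitrophenyl group.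

For compound 4 the expected step is a number 2 percentage points lower from compound 3 to compound 4 (within the scatter), none beyond the scatter. Compound 4 is estimated at 41%, with an expected range from 27% to 55%.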

Compound 4, a percentage reported as inhibition, at one concentration (the size of the read-out at that concentration, not a potency): 25.5%
Compound 4: middle estimate off by 15.5 percentage points, on the high side; measured number outside the range, below it.
By their numbers in this assay, from the lowest: compound 4; then compounds 1, 3 and 2 (each within the scatter of the next).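

In this assay this position proves sensitive to the aryl group after all: 2-nitrophenyl gives a number 17.5 percentage points lower from compound 3 to compound 4 (beyond the scatter), a number 18.5 percentage points lower from compound 2 to compound 4 (beyond the scatter) and a number 12 percentage points lower from compound 1 to compound 4 (beyond the scatter), each beyond the scatter, whereas the swaps among the three earlier aryl groups all stayed within it. Among these compounds, a substituent at the 2-position of the aryl ring is not enough on its own to produce the loss, since compound 1 also carries one, as 2,4-dimethoxyphenyl, and its number stands within the scatter of those of compound 2 and compound 3, so what sets compound 4 apart in this set is the 2-nitrophenyl group as a whole, the only aryl group here with a nitro group and with neither methoxy nor dimethylamino groups. No measurement on hand accounts for the loss.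

As far as these compounds go, whether the loss follows the nitro group itself or its place on the ring stays open, and 4-nitrophenyl or 3-nitrophenyl at this position would separate the two. Unsubstituted phenyl and 2-aminophenyl would show whether the low number is specific to the nitro group, and all of these numbers remain readings at one concentration, not potencies.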